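Ester for acid on the amide side chain

The compounds below may be only part of what the source reports. "The series", "measured", "known", "first", "only" and "open" are said of these compounds alone.

Compound 1 `C=CCN(CCCC(=O)O)C(=O)/C(C)=C/c1ccc(C(=O)Oc2ccc(C(=N)N)cc2)cc1` gives in an in vitro ADME assay on a cell-free system (plasma) for pharmacokinetics (a lower number here means that the compound disappears faster, a higher number that the compound lasts longer), a value of > 1 h, which is a limit of the assay and not a number (the limit of > 1 h in this assay, at which 1 of the 2 values shown sits). Compound 2 `CCOC(=O)CCCN(C(=O)/C(C)=C/c1ccc(C(=O)Oc2ccc(C(=N)N)cc2)cc1)C(C(=O)O)C(=O)OCC` gives 0.233 h in this assay. Compound 3 `C=CCN(CCC(=O)OCC)C(=O)/C(C)=C/c1ccc(C(=O)Oc2ccc(C(=N)N)cc2)cc1` awaits measurement; it differs from compound 1 by ethoxycarbonyl in place of carboxymethyl on a saturated chain carbon, two bonds along the chain from an amide-type nitrogen. Among the compounds with values here, no measured pair differs in one place, so the step size has to be judged; a move toward a shorter half-life, beyond the scatter, is expected because compound 2 with its ethoxycarbonyl groups gives 0.233 h. The expected step from compound 1 to compound 3 is an at least 3.3-fold lower number from compound 1 to compound 3 (0.52 log units; beyond the scatter). Compound 3 is estimated at 0.3 h, within 0.1 h to 1 h.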

Compound 3, half-life: < 0.0167 h
Compound 3: a limit, no number (the forecaster's own chance of this, stated with the estimate: 10%); at least 17-fold (1.25 log units) between middle value and limit.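

Ethoxycarbonyl in place of carboxymethyl on a saturated chain carbon, two bonds along the chain from an amide-type nitrogen, is a large change at this position in this assay (an at least 59-fold lower number from compound 1 to compound 3 (1.77 log units; beyond the scatter)). Compound 3 stands at a limit, not a number: the limit of < 0.0167 h in this assay, at which 1 of the 3 values shown sits.
Compound 1 also stands at a limit, not a number: the limit of > 1 h in this assay, at which 1 of the 3 values shown sits.
On these data alone, the full size of the step stays open. The change from 3-carboxypropyl to 2-(ethoxycarbonyl)ethyl alters both the end group and the chain, and an allyl amide bearing a 2-carboxyethyl chain would separate the two.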